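Swapping a benzyl amide for an anilide at compound 2

The source may report more compounds than this note shows. Statements on the series, on what has been measured and on what is new or still open speak of the compounds shown alone.

Measured in a functional assay on A549 cells (Homo sapiens) for cytotoxicity, read by MTT assay, with a stated time of 48 h; on this read-out higher numbers stand for weaker inhibition and lower numbers for stronger inhibition:
- Compound 1 `COc1cc([C@@H]2C[C@]2(CO)C(=O)Nc2ccccc2Cl)cc(OC)c1OC`: 4400 nM
- Compound 2 `COc1cc([C@@H]2C[C@]2(CO)C(=O)NCc2ccc(C)cc2)cc(OC)c1OC`: 10500 nM
- Compound 3 `COc1cc([C@H]2C[C@]2(CO)C(=O)NCc2ccc(C)cc2)cc(OC)c1OC`: 60700 nM

Compound 2, at 10500 nM, holds the middle place among these three numbers, the second highest. The next compound, compound 4 `COc1cc([C@@H]2C[C@]2(CO)C(=O)Nc2ccccc2)cc(OC)c1OC`, changes one group of compound 2: phenyl in place of 4-methylbenzyl on an amide-type nitrogen. Put simply, phenyl takes the place of 4-methylbenzyl on an amide-type nitrogen.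

The most relevant measured change is a 2.4-fold higher number from compound 1 to compound 2 (0.38 log units; beyond the scatter). Read in reverse, it suggests that replacing 4-methylbenzyl with 2-chlorophenyl lowers the number. The other measured change, a 5.8-fold higher number from compound 2 to compound 3 (0.76 log units; beyond the scatter), reflects (the fact that compounds 2 and 3 differ only in the configuration as drawn), so it says little about swapping a group.

Nothing measured separates phenyl from 2-chlorophenyl, so the direction is only a tentative expectation. The expected step is a 1.6-fold lower number from compound 2 to compound 4 (0.21 log units; within the scatter), a modest move toward stronger inhibition in this assay that may prove hard to distinguish from the scatter. For compound 4 the estimated value is 6500 nM, with an expected range of 2500 nM to 16000 nM.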

Compound 4, half-maximal inhibitory concentration: 24100 nM
For compound 4 the middle estimate is 3.7-fold (0.57 log units) below the measured one; the whole stated range lies below it.
By their numbers in this assay, from the lowest: compound 1; then compound 2; then compound 4; then compound 3.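

In this assay, the anilide link alone brings no gain over the benzyl amide: phenyl in place of 4-methylbenzyl on the amide-type nitrogen gives a 2.3-fold higher number from compound 2 to compound 4 (0.36 log units; beyond the scatter) and moves the number the opposite way from what compound 1 hinted. The chloro group therefore matters in this series, as hydrogen in place of chloro on an aromatic carbon gives a 5.5-fold higher number from compound 1 to compound 4 (0.74 log units; beyond the scatter) and leaves the unsubstituted anilide behind both compound 1 and compound 2. No measurement shown here explains why either step turns out as it does.

On these data alone, it remains open whether the gain is specific to chloro, or whether fluoro, a nitrile or an amine on the same phenyl ring would lower the number too. As far as these compounds go, the effect of the drawn configuration among the anilides also remains open.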